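The source may report more compounds than this note shows. Statements on the series, on what has been measured and on what is new or still open speak of the compounds shown alone.

Measured so far in a functional assay on cells for inhibition of Polyunsaturated fatty acid 5-lipoxygenase (Homo sapiens); a lower number here means a stronger inhibitor, a higher number a weaker inhibitor:
compound 1, `CSc1cccc(N2CCNC(=O)N2)c1`: 2200 nM
compound 2, `O=C1NCCN(c2ccccn2)N1`: 8600 nM
compound 3, `COc1cccc(N2CC(C)NC(=O)N2)n1`: 7100 nM

Among these three, compound 2 has the highest number. Compound 3 lies close to it, within the usual scatter of this assay, so nothing separates the two. Compound 1 gives a clearly lower number, beyond the scatter, and so is the stronger inhibitor of the pair.

Compound 4, `O=C1NCCN(c2cccc(-c3cccs3)n2)N1`, is not yet measured. It differs from compound 2 in one place: thiophen-2-yl in place of hydrogen on an aromatic carbon. Among the measured compounds shown here, because compound 1, the only compound here with a larger substituent on its aromatic ring, gives 2200 nM, a lower number than compound 2, a step toward a lower number seems plausible for compound 4 as well, though no directly comparable step has been measured. A moderate step downward, somewhat beyond the scatter, is expected: a 4.8-fold lower number from compound 2 to compound 4 (0.68 log units; beyond the scatter). The estimated value for compound 4 in this assay is 1800 nM, with a likely range from 350 nM to 9000 nM.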

Compound 4, half-maximal inhibitory concentration: 37000 nM
Estimate against measurement, compound 4: 21-fold (1.31 log units) below; measured number outside the range, above it.
By their numbers in this assay, from the lowest: compound 1; then compounds 3 and 2 (each within the scatter of the next); then compound 4.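

Placing thiophen-2-yl on the aromatic carbon next to the ring nitrogen brings a 4.3-fold higher number from compound 2 to compound 4 (0.63 log units; beyond the scatter) in this assay, so this one change weakens inhibition. This is the only direct comparison among the compounds shown, and it gives the first sign that a group added at this position can cost activity. Nothing available explains the loss.

As far as these compounds go, whether the loss comes with any group at this carbon or is particular to thiophen-2-yl stays open, and a methyl group, a methoxy group, a chlorine atom or a phenyl ring in the same place would help to tell these apart. From the compounds shown here alone, it is also open whether thiophen-2-yl would give a similar step on another carbon of the same ring.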